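Thioureas on a shared core: methyl to isopropyl

A few compounds are considered here, and "the series" means these few. Any claim that something is new, unique, unknown or untested is made for them only; others in the source may bear on it.

Compound 1 `C[C@@H](NC(=S)NCc1ccccc1)c1nc2ccccc2[nH]1` carries the highest of the two numbers measured in a functional assay on A549 cells (Homo sapiens) for cytotoxicity, read by MTT assay; a higher number here means a weaker inhibitor, a lower number a stronger inhibitor; compound 1 gives 18700 nM. Compound 2 `C[C@@H](NC(=S)Nc1cc(C(F)(F)F)cc(C(F)(F)F)c1)c1nc2ccccc2[nH]1` is the nearest entry, and in this assay compound 2 gives 15200 nM, a gap that lies within the scatter, so no order between compound 1 and compound 2 can be read from these two numbers. Compound 3 `C[C@H](NC(=S)NCc1ccccc1)c1nc2ccccc2[nH]1` is reported only as "not active" (no number reported) in this assay, with no number; it is linked to compound 1 by the fact that compounds 1 and 3 differ only in the configuration as drawn, nothing more is shown about it.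

Compound 4 `CC(C)[C@@H](NC(=S)NCc1ccccc1)c1nc2ccccc2[nH]1` is not yet measured. Its difference from compound 1 is isopropyl in place of methyl on a saturated chain carbon bound to an amide-type nitrogen and an aromatic carbon. Among the compounds with values here, no measured pair covers a change of this kind, so the size of the step cannot be read from earlier steps. The expectation is that the step from compound 1 to compound 4 stays within the scatter, with no clear direction, as expressed by a 1.2-fold lower number from compound 1 to compound 4 (0.07 log units; within the scatter). For compound 4 in this assay the estimate is 16000 nM, with a range from 5000 nM to 50000 nM.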

Compound 4, half-maximal inhibitory concentration: 11300 nM
Estimate against measurement, compound 4: 1.4-fold (0.15 log units) above, and the stated range covers the measured number.
By their numbers in this assay, from the lowest: compounds 4, 2 and 1 (each within the scatter of the next).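

In this assay, isopropyl in place of methyl on a saturated chain carbon bound to an amide-type nitrogen and an aromatic carbon gives a 1.7-fold lower number from compound 1 to compound 4 (0.22 log units; within the scatter). Within the data shown here, this is the first step at this carbon with numbers at both ends, and it shows that the position carries isopropyl with a number still reported and no order readable between the two compounds. Among these compounds, the only earlier change at this carbon has a "not active" entry at one end and no number to size it: the fact that compounds 1 and 3 differ only in the configuration as drawn.

Still open, on these data alone, is whether a longer chain, a phenyl ring or an amine at this carbon would give a step beyond the scatter. Also open, as far as these compounds go, is whether the isopropyl compound with the opposite configuration as drawn would give a number at all in this assay.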